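Compound 1 and the unmeasured hydroxy step

A few compounds are considered here, and "the series" means these few. Any claim that something is new, unique, unknown or untested is made for them only; others in the source may bear on it.

Compound 1 `CC(C)=CCOc1ccc2c(c1)OC(c1cccc(F)c1)CC2=O` gives 4280 nM
Compound 2 `CC(C)=CCOc1ccc2c(c1)OC(c1ccc(C)cc1)CC2=O` gives 4440 nM

Both values come from a functional assay (on this read-out higher numbers stand for weaker inhibition and lower numbers for stronger inhibition), and lie within the scatter of each other. Among the compounds with values here, compound 1 therefore cannot be ranked against its only measured neighbour. Within the data shown here, the one measured step is small (a 1.0-fold higher number from compound 1 to compound 2 (0.02 log units; within the scatter)), and it places 4-methylphenyl in place of 3-fluorophenyl on a saturated ring carbon.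

Compound 3 `CC(C)=CCOc1cc(O)c2c(c1)OC(c1cccc(F)c1)CC2=O` departs from compound 1 at another site (hydroxy in place of hydrogen on an aromatic carbon). It carries hydroxy in place of hydrogen on an aromatic carbon, ortho to a fused ring and meta to the (3-methylbut-2-en-1-yl)oxy group. The measured step bears on this change only loosely, as it concerns a different place in the molecule. Among the measured compounds shown here, no measured compound carries this hydroxy, so the data give no direction, and the expectation is of no step beyond the scatter, with a real shift either way still possible.

The estimated step is small (a 1.2-fold lower number from compound 1 to compound 3 (0.09 log units; within the scatter)).

Compound 3 is expected at about (3500 nM), with an estimated range from (1000 nM) to (12000 nM).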

Compound 3, half-maximal inhibitory concentration: 7240 nM
The estimate for compound 3 lay 2.1-fold (0.32 log units) below the measured number; the measured number falls inside the stated range.
By their numbers in this assay, from the lowest: compounds 1, 2 and 3 (each within the scatter of the next).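

Hydroxy in place of hydrogen on an aromatic carbon, ortho to a fused ring and meta to a (3-methylbut-2-en-1-yl)oxy group, gives the first measured reading at this position, and in this assay the change amounts to a 1.7-fold higher number from compound 1 to compound 3 (0.23 log units; within the scatter). Together with the step at the saturated ring carbon, a 1.0-fold higher number from compound 1 to compound 2 (0.02 log units; within the scatter), this means that neither of the two single changes made to compound 1 moves the number beyond the scatter, so this hydroxy, like the change at the saturated ring carbon, cannot be said to matter on this read-out. Nothing available on these compounds offers an explanation for the size of this step.

The compounds shown leave open whether a methoxy group, an amine or a fluorine on the same aromatic carbon would also stay within the scatter, and whether the hydroxy would give a similar step alongside the 4-methylphenyl group of compound 2. They also say nothing about replacing the (3-methylbut-2-en-1-yl)oxy group with a shorter chain, such as methoxy, or with a longer chain.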